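A few compounds are considered here, and "the series" means these few. Any claim that something is new, unique, unknown or untested is made for them only; others in the source may bear on it.

Measured so far:
Compound 1 `CCCCOc1cccc(Nc2nc3nonc3nc2O)c1`: in an assay on mitochondria from L6 cells (Rattus norvegicus) for activation, with a stated time of 90 min (a lower number here means that less compound is needed, a higher number that more compound is needed for the effect), compound 1 gives 2300 nM.
Compound 2 `Oc1nc2nonc2nc1Nc1ccc(OCC(F)(F)F)c(F)c1`: compound 2 gives 10400 nM.
Compound 3 `Oc1nc2nonc2nc1Nc1ccccc1OC(F)(F)F`: compound 3 gives 7100 nM.

Compound 1 has the lowest number of the three, so it needs the least material for the effect; its gaps to compound 3 and to compound 2 both lie beyond the usual scatter. Compound 4 `Oc1nc2nonc2nc1Nc1cccc(OC(F)(F)F)c1` has not yet been measured. It differs from compound 1 in one place: trifluoromethyl in place of butyl on an oxygen on an aromatic ring. Among the compounds with values here, no measured pair shows this change on its own, so the expectation rests only on the spread of the three numbers, which all fall in a fairly narrow band. In this assay a step toward a higher number is expected, of modest size, given as a 1.7-fold higher number from compound 1 to compound 4 (0.24 log units; within the scatter). Compound 4 is therefore estimated at 4000 nM, with a range from 1500 nM to 12000 nM.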

Compound 4, half-maximal effective concentration: 5100 nM
Estimate against measurement, compound 4: 1.3-fold (0.11 log units) below; the measured number falls inside the stated range.
By their numbers in this assay, from the lowest: compound 1; then compounds 4, 3 and 2 (each within the scatter of the next, the first and the last beyond it).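

In this assay, within the data shown here, trifluoromethyl in place of butyl on an oxygen on an aromatic ring gives a 2.2-fold higher number from compound 1 to compound 4 (0.35 log units; beyond the scatter) as the first change that can be read on its own. The step is modest, so the butyl is not essential for the effect at this position, although more compound is needed without it. No measurement here explains the step.

On these data alone, it remains open whether a plain methyl or a longer chain such as hexyl on this oxygen would give a lower or higher number, and how an amine in place of the oxygen would compare.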